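Added Chloro on a Sulfonyl Benzyl Cyclohexene Ester Series

This account rests on a few compounds, and the source may have more. Where it says the series, first, only, none or still open, it means among the compounds named here.

Compound 1 `CCOC(=O)C1=CCCCC1S(=O)(=O)Cc1cccc(Cl)c1` carries a 3-chlorophenyl group on a saturated chain carbon bound to a sulfonyl sulfur. In a functional assay on RAW264.7 cells (Mus musculus), read by fluorescence (on this read-out higher numbers stand for weaker inhibition and lower numbers for stronger inhibition), compound 1 gives 14 nM. Compound 2 `CCOC(=O)C1=CCCCC1S(=O)(=O)Cc1ccc(Cl)cc1` differs from it in its core by 4-chlorophenyl in place of 3-chlorophenyl on a saturated chain carbon bound to a sulfonyl sulfur. In this assay compound 2 gives 101 nM, a step of a 7.2-fold higher number from compound 1 to compound 2 (0.86 log units; beyond the scatter). Compound 3 `CCOC(=O)C1=CCCCC1S(=O)(=O)Cc1cccc(Cl)c1Cl` arises from compound 1 by chloro in place of hydrogen on an aromatic carbon. In this assay compound 3 gives 65 nM, so the added chloro made a 4.6-fold higher number from compound 1 to compound 3 (0.67 log units; beyond the scatter). The numbers of compound 2 and compound 3 lie within the scatter of each other, so no order between them is claimed.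

Compound 4 `CCOC(=O)C1=CCCCC1S(=O)(=O)Cc1ccc(Cl)cc1Cl` is not yet measured. It arises from compound 2 by chloro in place of hydrogen on an aromatic carbon. Among the compounds with values here, this is the same kind of change as the one that turned compound 1 into compound 3, but not the same: in compound 3 the entering chloro sits ortho to a chloro group and ortho to a large group, whereas in compound 4 it sits ortho to a large group and meta to a chloro group. Within the data shown here, the surroundings of the place thus differ, and no measured pair shows what that difference does.

Because the same kind of change gave a 4.6-fold higher number from compound 1 to compound 3 (0.67 log units; beyond the scatter), compound 4 is expected to show a step of a 3.5-fold higher number from compound 2 to compound 4 (0.54 log units; beyond the scatter). Compound 4 is therefore estimated at 350 nM in this assay. For compound 4 the expected range runs from 120 nM to 1200 nM, the width reflecting the changed surroundings of the place.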

Compound 4, half-maximal inhibitory concentration: 60 nM
Compound 4: middle estimate off by 5.8-fold (0.77 log units), on the high side; measured number outside the range, below it.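

In this assay, within the data shown here, chloro in place of hydrogen on an aromatic carbon gives a 1.7-fold lower number from compound 2 to compound 4 (0.23 log units; within the scatter), so on the core of compound 2 the added chloro produces no step that can be told from the scatter. Set beside the earlier step, this shows that the change does not carry over with a fixed size from one core to the other in this series: the same change on two cores in this assay, a 4.6-fold higher number (0.67 log units; beyond the scatter) from compound 1 to compound 3 and a 1.7-fold lower number (0.23 log units; within the scatter) from compound 2 to compound 4, 7.8-fold (0.89 log units) apart, beyond the scatter of two such steps What this does not show is the reason for the gap, since there are only two pairs, and in compound 4 the entering chloro sits ortho to a large group and meta to a chloro group, a placement that no other measured pair isolates, so the surroundings of the place cannot be separated from any other difference between the two cores.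

The compounds shown all keep the ethyl ester and carry only chloro on the aromatic ring, so it remains open whether a fluoro or a methoxy group at the same place would follow either step. On these data alone, it is also open how a carboxylic acid in place of the ester would behave on these cores.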